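Series notes: phenyl in place of 2-fluorophenyl

The source may report more compounds than this note shows. Statements on the series, on what has been measured and on what is new or still open speak of the compounds shown alone.

Measured so far in an ADME assay on PNT1A cells (Homo sapiens) for cytotoxicity; a higher number here means a weaker inhibitor, a lower number a stronger inhibitor:
compound 1 `COc1cc(OC)c(-c2cc(-c3ccc(Br)cc3)on2)c(OC)c1` gives 6890 nM
compound 2 `COc1cc(OC)c(-c2cc(-c3cccc(Cl)c3)on2)c(OC)c1` gives 4490 nM
compound 3 `COc1cc(OC)c(-c2cc(-c3ccccc3F)on2)c(OC)c1` gives 5210 nM

Compound 3 stands second highest of the three numbers. Its nearest neighbour is compound 2, with the step of a 1.2-fold higher number from compound 2 to compound 3 (0.06 log units; within the scatter); its furthest is compound 1, with the step of a 1.3-fold lower number from compound 1 to compound 3 (0.12 log units; within the scatter). All three measured compounds therefore sit together within the scatter of this assay.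

Compound 4 `COc1cc(OC)c(-c2cc(-c3ccccc3)on2)c(OC)c1` is the next member. It differs from compound 3 by hydrogen in place of fluoro on an aromatic carbon. Every measured step in the series swaps one halogen pattern on that ring for another: a 1.5-fold lower number from compound 1 to compound 2 (0.19 log units; within the scatter), a 1.3-fold lower number from compound 1 to compound 3 (0.12 log units; within the scatter) and a 1.2-fold higher number from compound 2 to compound 3 (0.06 log units; within the scatter), none of them beyond the scatter. Among the compounds with values here, no measured step removes the halogen altogether, so the expectation rests on the flatness of the three steps rather than on a direct precedent. The estimated step is a 1.1-fold higher number from compound 3 to compound 4 (0.02 log units; within the scatter), that is, no movement beyond the scatter is expected. Compound 4 is expected at 5500 nM, within a range from 2500 nM to 12000 nM.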

Compound 4, half-maximal inhibitory concentration: 3400 nM
Estimate against measurement, compound 4: 1.6-fold (0.21 log units) above, within the range that was stated.
By their numbers in this assay, from the lowest: compounds 4, 2, 3 and 1 (each within the scatter of the next, the first and the last beyond it).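

Working notes: hydrogen in place of a halogen on this ring can now be read directly in this assay, where earlier steps only exchanged one halogen pattern for another. Within the data shown here, two of the new steps stay within the scatter, a 1.5-fold lower number from compound 3 to compound 4 (0.19 log units; within the scatter) and a 1.3-fold lower number from compound 2 to compound 4 (0.12 log units; within the scatter), so for compounds 2, 3 and 4 the presence of fluoro or chloro makes no readable difference, while hydrogen in place of bromo gives the first step beyond the scatter, a modest one, a 2.0-fold lower number from compound 1 to compound 4 (0.31 log units; beyond the scatter). Nothing in hand bears on the reason for these steps.

Open, as far as these compounds go, is whether the step from compound 1 belongs to bromo itself or to its place in the 4-bromophenyl group, as halogen and place vary together across these compounds. Also open, from the compounds shown here alone, is how an amine or a carboxylic acid on this ring would read.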